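This account rests on a few compounds, and the source may have more. Where it says the series, first, only, none or still open, it means among the compounds named here.

Three measured compounds share one core. Compound 1 `CCOC(=O)CCCCCOc1cccc(CN(C(=O)c2ccc(-c3cccc(-c4ccccc4)c3)cc2)C(C)C)c1` carries a phenyl on an aromatic carbon. In an ADME assay on HEK293 cells (Homo sapiens) for cytotoxicity, read by CellTiter-Glo and resazurin assay, with a stated time of 72 h (on this read-out higher numbers stand for an effect only at larger amounts of compound and lower numbers for an effect already at smaller amounts), compound 1 reaches only a limit of the assay, > 26000 nM, not a number. Compound 2 `CCOC(=O)CCCCCOc1cccc(CN(C(=O)c2ccc(-c3cccc(C(C)=O)c3)cc2)C(C)C)c1` carries an acetyl in place of that phenyl; in this assay compound 2 likewise gives only a limit, > 26000 nM. Compound 3 `CCOC(=O)CCCCCOc1cccc(CN(C(=O)c2ccc(-c3cccc(OCC(C)C)c3)cc2)C(C)C)c1` carries an isobutoxy on that aromatic carbon; in this assay compound 3 again gives only a limit, > 26000 nM. The steps a step that the two limits leave unreadable from compound 1 to compound 2, a step that the two limits leave unreadable from compound 1 to compound 3 and a step that the two limits leave unreadable from compound 2 to compound 3 therefore cannot be sized, since (the limit of > 26000 nM in this assay, at which 3 of the 3 values shown sit). Compound 3 thus stands where every measured member stands, at the limit and without a number.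

Compound 4 `CCOC(=O)CCCCCOc1cccc(CN(C(=O)c2ccc(-c3cccc(OCc4ccccc4)c3)cc2)C(C)C)c1` differs from compound 3 by phenyl in place of isopropyl on a saturated chain carbon bound to an oxygen on an aromatic ring. Within the data shown here, no measured step bears directly on this change; the only guidance is that (the limit of > 26000 nM in this assay, at which 3 of the 3 values shown sit), with none of the three groups tried on that aromatic carbon reading out a number. For compound 4 the expectation is therefore that the same limit is reached again, meaning an expected step that the limit leaves unreadable from compound 3 to compound 4. The estimate for compound 4 in this assay is 35000 nM, within 15000 nM to 90000 nM.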

Compound 4, half-maximal effective concentration: > 26000 nM
Compound 4 ended at the assay's limit; the forecaster's own chance of this, stated with the estimate: 85%; the middle value does not contradict the limit.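

Compound 4 gives only a limit, as do compound 1, compound 2 and compound 3, so no step among these compounds can be read: (the limit of > 26000 nM in this assay, at which 4 of the 4 values shown sit). The compounds shown leave open whether any group on that aromatic carbon gives a number rather than a limit in this assay.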